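A Trifluoromethyl Swap on the Aryl Urea of Compound 2

This account rests on a few compounds, and the source may have more. Where it says the series, first, only, none or still open, it means among the compounds named here.

In an in vitro assay on BHK cells for binding affinity to Glucagon receptor (Homo sapiens) (on this read-out lower numbers stand for stronger inhibition and higher numbers for weaker inhibition), compound 2 `Cc1cc(C)cc(NC(=O)N(Cc2ccc(C(=O)NC[C@@H](O)C(=O)O)cc2)[C@H]2CC[C@H](C(C)(C)C)CC2)c1` gives 27 nM, the highest of the three numbers recorded. Compound 1 `CC(C)(C)[C@H]1CC[C@H](N(Cc2ccc(C(=O)NCCC(=O)O)cc2)C(=O)Nc2cc(C(F)(F)F)cc(C(F)(F)F)c2)CC1` gives 16 nM, a difference from compound 2 that sits within the scatter, while compound 3 `O=C(NC[C@@H](O)C(=O)O)c1ccc(CN(C(=O)Nc2cccc(Br)c2)c2ccc(C3CCCCC3)cc2)cc1` gives 8 nM, a gap that lies beyond it. Compound 4 `Cc1cc(NC(=O)N(Cc2ccc(C(=O)NC[C@@H](O)C(=O)O)cc2)[C@H]2CC[C@H](C(C)(C)C)CC2)cc(C(F)(F)F)c1` is not yet measured; it differs from compound 2 by trifluoromethyl in place of methyl on an aromatic carbon, meta to a large group and meta to a methyl group. Within the data shown here, no single-change step among the measured compounds shows what this swap does, so compound 4 is expected to give 15 nM, between 5 nM and 45 nM. The step of a 1.8-fold lower number from compound 2 to compound 4 (0.26 log units; within the scatter) is expected to be modest, leaning toward a lower number, and may well stay within the scatter.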

Compound 4, half-maximal inhibitory concentration: 10 nM
Beside the measured number, compound 4's estimate is 1.5-fold (0.18 log units) above it; measured number inside the range.
By their numbers in this assay, from the lowest: compounds 3, 4, 1 and 2 (each within the scatter of the next, the first and the last beyond it).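

In this assay, trifluoromethyl in place of methyl on an aromatic carbon, meta to a large group and meta to a methyl group, gives a 2.7-fold lower number from compound 2 to compound 4 (0.43 log units; beyond the scatter). This is the first single-change step among these compounds, and it shows that the number responds to a change at this position of the 3,5-dimethylphenyl group. The compounds shown offer no evidence on why the number moves.

Still open, as far as these compounds go, is what a chlorine atom, a methoxy group or a nitrile would give on the same carbon. Also open, from the compounds shown here alone, is whether trifluoromethyl in place of the remaining methyl would give a further step.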